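Methoxymethyl to hydroxymethyl: the next step in the series

The source may hold more compounds than are shown below. What is called first, only, known or untested is meant among the compounds shown, and "the series" means these compounds.

Of the compounds shown here, two on one shared core have been measured so far. In a functional assay on KB cells (Homo sapiens) for cytotoxicity, read by sulforhodamine B assay, with a stated time of 3 days (a higher number here means that more compound is needed for the effect, a lower number that less compound is needed), compound 1 `COC(=O)c1c(C)coc1-c1ccc2c(c1OC)CCCC2(C)C` gives 53.4 uM, and compound 2 `COCc1c(C)coc1-c1ccc2c(c1OC)CCCC2(C)C` gives 11.5 uM, the lower of the two numbers. Among the measured compounds shown here, the only measured step is a 4.6-fold lower number from compound 1 to compound 2 (0.67 log units; beyond the scatter), with methoxymethyl in place of methoxycarbonyl on an aromatic carbon.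

Next comes compound 3 `COc1c(-c2occ(C)c2CO)ccc2c1CCCC2(C)C`. The change is hydrogen in place of methyl on an oxygen on a saturated carbon, with hydrogen in place of methyl on an oxygen on a saturated carbon, so that methoxymethyl becomes hydroxymethyl.

For the measured compounds named here, only the step from compound 1 to compound 2 bears on this change, as it altered the same group. That single step, a 4.6-fold lower number from compound 1 to compound 2 (0.67 log units; beyond the scatter), shows that a change to this group can move the number in this assay. It does not show the direction of the present, smaller edit. A smaller step than that one is expected, perhaps within the scatter, with a slight lean towards a higher number. The estimated step is a 1.6-fold higher number from compound 2 to compound 3 (0.19 log units; within the scatter). The expected value for compound 3 is 18 uM, within an estimated range of 6 uM to 50 uM.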

Compound 3, concentration for half-maximal effect: 25.3 uM
Estimate against measurement, compound 3: 1.4-fold (0.15 log units) below; the range from low to high includes it.
By their numbers in this assay, from the lowest: compound 2; then compound 3; then compound 1.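

In this assay the change from methoxymethyl to hydroxymethyl has a readable effect of its own, a 2.2-fold higher number from compound 2 to compound 3 (0.34 log units; beyond the scatter), so the methyl on this oxygen on a saturated carbon counts for the number, and replacing it with hydrogen gives back part of the drop seen on leaving methoxycarbonyl. Hydroxymethyl still stays on the lower side of the ester, a 2.1-fold lower number from compound 1 to compound 3 (0.32 log units; beyond the scatter), so across these three compounds both groups without the carbonyl give lower numbers than methoxycarbonyl, no compound goes against this, and methoxymethyl gives the lowest number of the three. Nothing at hand accounts for this order, and the numbers alone give only the ranking of the three groups.

Still open, going by these compounds, is whether a longer chain on this oxygen, such as ethoxymethyl, would continue the gain seen with methoxymethyl, and whether an aminomethyl group or a carboxylic acid at this place would fall inside or outside the range these three groups span. On these data alone, all three compounds share one core, so it also remains open whether the same order of groups would hold with any other part of that core changed.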